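A few compounds are considered here, and "the series" means these few. Any claim that something is new, unique, unknown or untested is made for them only; others in the source may bear on it.

Measured compounds:
compound 1 `CNC(=O)CCCCCCCn1nc(-c2cnc3[nH]ccc3c2)c2c(N)ncnc21` gives 35900 nM
compound 2 `Nc1ncnc2c1c(-c1cnc3[nH]ccc3c1)nn2CCCCCCCCC(=O)NO` gives 14900 nM
compound 3 `Nc1nc2cc(-c3nn(CCCCCCCCC(=O)NO)c4ncnc(N)c34)ccc2o1` gives 24000 nM

All three values come from a functional assay on PLC-PRF-5 cells (Homo sapiens) for inhibition, read by MTT assay, with a stated time of 72 h; a lower number here means a stronger inhibitor, a higher number a weaker inhibitor. Compound 2 and compound 1 share a core and differ only at the chain end: methylcarbamoyl in place of (hydroxycarbamoyl)methyl on a saturated chain carbon, seven bonds along the chain from an aromatic nitrogen. That change gave a 2.4-fold higher number from compound 2 to compound 1 (0.38 log units; beyond the scatter). Compound 2 and compound 3 differ in the group on the core, (a group of 10 heavy atoms (7 carbon, 2 nitrogen, 1 oxygen; one five-membered aromatic ring with 2 hetero atoms, one six-membered aromatic ring of carbon only) in place of a group of 9 heavy atoms (7 carbon, 2 nitrogen; one five-membered aromatic ring with 1 hetero atom, one six-membered aromatic ring with 1 hetero atom), on an aromatic carbon), a step of a 1.6-fold higher number from compound 2 to compound 3 (0.21 log units; within the scatter).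

Compound 4 `CNC(=O)CCCCCCCn1nc(-c2ccc3oc(N)nc3c2)c2c(N)ncnc21` has not been measured. It carries the core of compound 3 and the chain end of compound 1, so the change from compound 3 to compound 4 is methylcarbamoyl in place of (hydroxycarbamoyl)methyl on a saturated chain carbon, seven bonds along the chain from an aromatic nitrogen, the same change at the same place as that from compound 2 to compound 1. Because the earlier step was a 2.4-fold higher number from compound 2 to compound 1 (0.38 log units; beyond the scatter), the step expected for compound 4 is a 2.4-fold higher number from compound 3 to compound 4 (0.38 log units; beyond the scatter), though this rests on a single pair. Compound 4 is therefore estimated at 58000 nM, with a likely range from 25000 nM to 130000 nM.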

Compound 4, half-maximal inhibitory concentration: 30500 nM
Compound 4: the middle estimate sits 1.9-fold (0.28 log units) above what was measured; the range from low to high includes it.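

In this assay, putting methylcarbamoyl in place of (hydroxycarbamoyl)methyl on the second core gave a 1.3-fold higher number from compound 3 to compound 4 (0.10 log units; within the scatter), and this step does not differ measurably from the same change on the first core: the same change on two cores in this assay, a 2.4-fold higher number (0.38 log units; beyond the scatter) from compound 2 to compound 1 and a 1.3-fold higher number (0.10 log units; within the scatter) from compound 3 to compound 4, 1.9-fold (0.28 log units) apart, within the scatter of two such steps. Changing the group on the core while keeping the methylcarbamoyl end gave a 1.2-fold lower number from compound 1 to compound 4 (0.07 log units; within the scatter), which also agrees with the same core change made with the other chain end: the same change on two cores in this assay, a 1.6-fold higher number (0.21 log units; within the scatter) from compound 2 to compound 3 and a 1.2-fold lower number (0.07 log units; within the scatter) from compound 1 to compound 4, 1.9-fold (0.28 log units) apart, within the scatter of two such steps. So the chain-end change carried from one core to the other within the scatter, but two pairs cannot show that it would carry to further cores, and one of the two steps is itself within the scatter.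

The compounds shown leave open how other chain ends, such as a carboxylic acid or a primary amide, would behave. From the compounds shown here alone, a longer chain also remains untested here.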